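The source may hold more compounds than are shown below. What is called first, only, known or untested is meant among the compounds shown, and "the series" means these compounds.

Compound 1 `COc1ccc(C(=O)OC(CCN(C)C)c2ccc(Cl)cc2)cc1`: in an assay on NIH3T3 cells with Urotensin-2 receptor (Homo sapiens) as the target (a lower number here means that less compound is needed, a higher number that more compound is needed for the effect), compound 1 gives 2190 nM.
Compound 2 `Cc1ccsc1C(=O)OC(CCN(C)C)c1ccc(Cl)cc1`: in this assay compound 2 gives 2510 nM.
Compound 3 `COc1cccc(C(=O)OC(CCN(C)C)c2ccc(Cl)cc2)c1C`: in this assay compound 3 gives 1950 nM.

Compound 3 stands within the usual scatter of both compound 1 and compound 2, so the three numbers cannot be told apart. Compound 4 `Cc1c(Cl)cccc1C(=O)OC(CCN(C)C)c1ccc(Cl)cc1` differs from compound 3 by chloro in place of methoxy on an aromatic carbon. For the measured compounds named here, no measured step swaps exactly these two groups. Going by the values given here, the one step that touches the ester-bound ring, a 1.1-fold higher number from compound 1 to compound 2 (0.06 log units; within the scatter), exchanged that whole ring and still stayed within the scatter. The account therefore expects no step beyond the scatter in this assay for compound 4, that is a 1.0-fold higher number from compound 3 to compound 4 (0.01 log units; within the scatter). For compound 4 the estimate in this assay is 2000 nM, with a range from 900 nM to 4500 nM.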

Compound 4, half-maximal effective concentration: 1120 nM
Estimate against measurement, compound 4: 1.8-fold (0.25 log units) above; low and high end bracket the measured number.
By their numbers in this assay, from the lowest: compounds 4, 3, 1 and 2 (each within the scatter of the next, the first and the last beyond it).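

Chloro in place of methoxy on this aromatic carbon, ortho to a methyl group, gives a 1.7-fold lower number from compound 3 to compound 4 (0.24 log units; within the scatter) in this assay and so does not separate the two compounds. The exchange of the whole group on the carbonyl carbon gives a 2.0-fold lower number from compound 1 to compound 4 (0.29 log units; within the scatter) and likewise stays unresolved, whereas a 2.2-fold lower number from compound 2 to compound 4 (0.35 log units; beyond the scatter) is the first listed step to pass the scatter, though only modestly. No supporting evidence is available to explain these results. On these data alone, whether bromo or a nitrile on this aromatic carbon would give a step beyond the scatter remains open.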